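Chloro for Fluoro: Estimating the Affinity of Compound 4

The compounds below may be only part of what the source reports. "The series", "measured", "known", "first", "only" and "open" are said of these compounds alone.

Three compounds have been measured in an assay on isolated protein for binding affinity to melanin-concentrating hormone receptor 1 (Homo sapiens); a lower number here means a stronger inhibitor, a higher number a weaker inhibitor:

Compound 1, `CN1CCN(CCCN(c2nc3cc(F)c(F)cc3[nH]2)[C@@H]2CC[C@]3(c4cccc(C#N)c4)C[C@@H]3C2)CC1`, gives 8.4 nM.
Compound 2, `CN1CCN(CCCN(c2nc3cc(F)c(Cl)cc3[nH]2)[C@@H]2CC[C@]3(c4cccc(C#N)c4)C[C@@H]3C2)CC1`, gives 6.2 nM.
Compound 3, `CS(=O)(=O)N1CCC(CN(c2nc3cc(F)c(F)cc3[nH]2)[C@@H]2CC[C@]3(c4cccc(C#N)c4)C[C@@H]3C2)CC1`, gives 27 nM.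

Compound 3 stands with the highest number of the three: compound 1 lies nearer to it, with a 3.2-fold higher number from compound 1 to compound 3 (0.51 log units; beyond the scatter) separating them, and compound 2 lies furthest away. Compound 3 and compound 1 share everything except the chain on the nitrogen attached to the shared core, where compound 3 carries a 1-(methylsulfonyl)piperidin-4-yl group instead of a 2-(4-methylpiperazin-1-yl)ethyl group.

Compound 4, `CS(=O)(=O)N1CCC(CN(c2nc3cc(F)c(Cl)cc3[nH]2)[C@@H]2CC[C@]3(c4cccc(C#N)c4)C[C@@H]3C2)CC1`, is not yet measured. It differs from compound 3 in one place: chloro in place of fluoro on an aromatic carbon. The same exchange has already been followed on the other chain, where a 1.4-fold lower number from compound 1 to compound 2 (0.13 log units; within the scatter) stayed within the scatter. Among the compounds with values here, only that one step bears on the question, and it suggests that exchanging fluoro for chloro makes little difference in this assay.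

In this assay the expected step is therefore small, estimated as a 1.4-fold lower number from compound 3 to compound 4 (0.15 log units; within the scatter). Compound 4 is expected to show 19 nM, with a likely range from 8 nM to 45 nM.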

Compound 4, inhibition constant: 6.7 nM
Compound 4: middle estimate off by 2.8-fold (0.45 log units), on the high side; the whole stated range lies above it.
By their numbers in this assay, from the lowest: compounds 2, 4 and 1 (each within the scatter of the next); then compound 3.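

In this assay, chloro in place of fluoro on this aromatic carbon is not a fixed increment. With the 1-(methylsulfonyl)piperidin-4-yl group on the chain, the exchange gives a 4.0-fold lower number from compound 3 to compound 4 (0.61 log units; beyond the scatter), so the size of the step depends on which chain the shared core carries: the same change on two cores in this assay, a 1.4-fold lower number (0.13 log units; within the scatter) from compound 1 to compound 2 and a 4.0-fold lower number (0.61 log units; beyond the scatter) from compound 3 to compound 4, 3.0-fold (0.47 log units) apart, beyond the scatter of two such steps. Read the other way, the chain exchange that raised the number with two fluoro groups on the ring leaves a 1.1-fold higher number from compound 2 to compound 4 (0.03 log units; within the scatter) once chloro is present, so the two changes do not simply add up: the same change on two cores in this assay, a 3.2-fold higher number (0.51 log units; beyond the scatter) from compound 1 to compound 3 and a 1.1-fold higher number (0.03 log units; within the scatter) from compound 2 to compound 4, 3.0-fold (0.47 log units) apart, beyond the scatter of two such steps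

Four compounds with two chains and two groups at this position cannot show whether this dependence extends to other groups on the same aromatic carbon, such as bromo, methyl or methoxy, or to a third chain on the nitrogen, such as a longer chain ending in a carboxylic acid. What lies behind the difference between the two chloro-for-fluoro steps also stays open.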